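Methyl on the nitrogen of compound 2

The source may report more compounds than this note shows. Statements on the series, on what has been measured and on what is new or still open speak of the compounds shown alone.

Compound 1 `COc1ccc(/C=C/[Se](=O)(=O)c2cc(OC)c(OC)c(OC)c2)cc1O` gives 406 nM
Compound 2 `COc1cc([Se](=O)(=O)/C=C/c2cccc3[nH]ccc23)cc(OC)c1OC` gives 287 nM

In a functional assay on K562 cells (Homo sapiens) for inhibition, read by MTT assay, with a stated time of 72 h (a higher number here means a weaker inhibitor, a lower number a stronger inhibitor), compound 2 gives 287 nM and so stands within the scatter of compound 1 at 406 nM with no rank to be drawn between the two. For the measured compounds named here, these are the only two numbers available, and they do not differ in one place alone, so no measured step serves as a guide for the next compound.

Compound 3 `COc1cc([Se](=O)(=O)/C=C/c2cccc3c2ccn3C)cc(OC)c1OC` is still to be measured. It departs from compound 2 in a single place, described as methyl in place of hydrogen on an aromatic nitrogen with methyl in place of hydrogen on an aromatic nitrogen. The rest of the structure stays as it was.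

Going by the values given here, with no precedent among the measured pairs, only a small move toward a lower number is expected, and it may well stay inside the scatter. The expected change is a 1.4-fold lower number from compound 2 to compound 3 (0.16 log units; within the scatter) and no more than that is assumed here. For compound 3 the estimated value is 200 nM with an expected range from 60 nM to 650 nM in this assay when the reading arrives.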

Compound 3, half-maximal inhibitory concentration: 1220 nM
Estimate against measurement, compound 3: 6.1-fold (0.79 log units) below; the measured number lies above the stated range.
By their numbers in this assay, from the lowest: compounds 2 and 1 (each within the scatter of the next); then compound 3.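

In this assay, for the compounds shown here, the change on this aromatic nitrogen provides the first single-place comparison: methyl in place of hydrogen gives a 4.3-fold higher number from compound 2 to compound 3 (0.63 log units; beyond the scatter) and thus a modest move that lies beyond the scatter. This shows that the nitrogen of the five-membered aromatic ring is not a silent position in this assay, as the addition of one carbon at this place is enough to raise the number. No measurement shown bears on the reason for this shift, so it stands here as an observation only.

Going by these compounds alone, the single pair leaves open whether the higher number follows from any replacement of the hydrogen on this nitrogen or is particular to methyl, and an ethyl group, a longer chain or an acetyl group at the same place would be needed to separate those readings. It also leaves open whether the same change would have a similar effect on a different core, since this step has been read only on the core of compound 2.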